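From 3-chlorophenyl to 4-(trifluoromethyl)phenyl on compound 2

A few compounds are considered here, and "the series" means these few. Any claim that something is new, unique, unknown or untested is made for them only; others in the source may bear on it.

In a functional assay on A549 cells (Homo sapiens) for antiproliferative activity, read by MTT assay, with a stated time of 48 h (a higher number here means a weaker inhibitor, a lower number a stronger inhibitor), compound 2 (`COc1ccc(/C=C/c2cc(OC)cc(OC)c2/C=C/C(=O)c2cccc(Cl)c2)cc1`) gives 5.6 ug/mL and compound 1 (`CCCCCCOc1ccc(C(=O)/C=C/c2c(/C=C/c3ccc(OC)cc3)cc(OC)cc2OC)cc1`) gives 8.4 ug/mL with the two values within the usual scatter of each other. Compound 3 (`COc1ccc(/C=C/c2cc(OC)cc(OC)c2/C=C/C(=O)c2ccc(C(F)(F)F)cc2)cc1`) carries 4-(trifluoromethyl)phenyl in place of 3-chlorophenyl on a carbonyl carbon. For the measured compounds named here, no two measured compounds differ in only one place, so the main guide is the value of compound 2 (5.6 ug/mL). The expected change (a 1.1-fold higher number from compound 2 to compound 3 (0.03 log units; within the scatter)) stays within the scatter, with no direction favoured. Compound 3 is estimated at 6 ug/mL (range 2.5 ug/mL to 14 ug/mL).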

Compound 3, half-maximal inhibitory concentration: 7.8 ug/mL
Compound 3: the middle estimate sits 1.3-fold (0.11 log units) below what was measured; the range from low to high includes it.
By their numbers in this assay, from the lowest: compounds 2, 3 and 1 (each within the scatter of the next).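

In this assay, 4-(trifluoromethyl)phenyl in place of 3-chlorophenyl on the carbonyl carbon gives a 1.4-fold higher number from compound 2 to compound 3 (0.14 log units; within the scatter), and trifluoromethyl in place of hexyloxy on an aromatic carbon gives a 1.1-fold lower number from compound 1 to compound 3 (0.03 log units; within the scatter). For the compounds shown here, for the first time, these single changes can be read directly: neither step at this position moves the result beyond the scatter, so compounds 1, 2 and 3 cannot be told apart here. No measurement shown explains this result. Still open, going by these compounds, is whether an amine or a carboxylic acid on this ring would give a step beyond the scatter. A plain phenyl ring would also show whether these groups matter at all.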